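A few compounds are considered here, and "the series" means these few. Any claim that something is new, unique, unknown or untested is made for them only; others in the source may bear on it.

Working notes on the series. Within the data shown here, compound 1 `COc1ccc(/C=C/C(=O)Nc2cc3c(Nc4ccc(F)c(Cl)c4)ncnc3cc2OC)c(OC)c1` is the only member carrying the smaller ether on the shared core; in a functional assay on HeLa cells (Homo sapiens) for cytotoxicity, read by MTT assay, with a stated time of 72 h (on this read-out higher numbers stand for weaker inhibition and lower numbers for stronger inhibition), compound 1 is recorded as "not determined" (no result reported), so it contributes no number. Among the measured compounds shown here, compound 2 `COc1cc(/C=C/C(=O)Nc2cc3c(Nc4ccc(F)c(Cl)c4)ncnc3cc2O[C@H]2CCOC2)cc(OC)c1O` is therefore the sole compound with a result: in this assay compound 2 gives 27400 nM, and it stands alone on the numbers, with nothing to rank it against.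

Compound 3 `O=C(/C=C/c1cc(Br)c(O)c(Br)c1)Nc1cc2c(Nc3ccc(F)c(Cl)c3)ncnc2cc1O[C@H]1CCOC1` differs from compound 2 in one place: 3,5-dibromo-4-hydroxyphenyl in place of 4-hydroxy-3,5-dimethoxyphenyl on a double-bonded chain carbon bound to a double-bonded chain carbon. For the measured compounds named here, no pair with a measured step exists here, so the size of this change in this assay cannot be read from the data. The expectation is a step from compound 2 to compound 3 of a 1.4-fold lower number from compound 2 to compound 3 (0.14 log units; within the scatter), that is, a modest move toward stronger inhibition but one that may not exceed the scatter. Compound 3 is estimated at 20000 nM in this assay, with a range from 6000 nM to 70000 nM.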

Compound 3, half-maximal inhibitory concentration: 27700 nM
Beside the measured number, compound 3's estimate is 1.4-fold (0.14 log units) below it; measured number inside the range.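

In this assay, among these compounds, the first readable step at this position is a 1.0-fold higher number from compound 2 to compound 3 (0.00 log units; within the scatter), so compound 2 and compound 3 cannot be told apart. On a double-bonded chain carbon bound to a double-bonded chain carbon, 3,5-dibromo-4-hydroxyphenyl and 4-hydroxy-3,5-dimethoxyphenyl thus give equivalent results, although the two groups differ in their atoms and hydrogen-bond acceptor counts. No measurement at hand accounts for this equivalence.

Steps involving compound 1 cannot be read, so the contribution of the smaller ether on the shared core stays unknown. Going by these compounds, it also remains open whether a group without the phenol hydroxyl, such as a dimethylamino group or a carboxylic acid on the aromatic ring, would separate from these two compounds.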